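Thiosemicarbazones with a quinoline-derived core against colon cancer cells

The source may report more compounds than this note shows. Statements on the series, on what has been measured and on what is new or still open speak of the compounds shown alone.

Measured compounds:
- compound 1, `Fc1cccc(NC(=S)N/N=C/c2ccc3ccccc3n2)c1`, 74700 nM
- compound 2, `S=C(N/N=C/c1ccc2ccccc2n1)Nc1ccc(Cl)cc1`, 97200 nM
- compound 3, `FC(F)(F)c1ccc(NC(=S)N/N=C/c2ccc3ccccc3n2)cc1`, 63900 nM

These three compounds share one core and differ only in the group carried on the aromatic ring attached to the amide-type nitrogen. All three were tested in a functional assay on HT-29 cells (Homo sapiens) for antiproliferative activity, read by sulforhodamine B assay, with a stated time of 72 h (a higher number here means a weaker inhibitor, a lower number a stronger inhibitor), and all three numbers are high, so each is a weak inhibitor. Compound 3 gives the lowest of the three numbers, but its gap to compound 1 and to compound 2 lies within the usual scatter, so no ordering among them can be claimed.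

The two measured steps are small: a 1.3-fold higher number from compound 1 to compound 2 (0.11 log units; within the scatter) and a 1.5-fold lower number from compound 2 to compound 3 (0.18 log units; within the scatter). Neither moves the number beyond the scatter.

Compound 4, `COc1ccc(NC(=S)N/N=C/c2ccc3ccccc3n2)cc1`, has not yet been measured. It differs from compound 3 in one place: methoxy in place of trifluoromethyl on an aromatic carbon. Within the data shown here, the step that bears most on this change is the one from compound 2 to compound 3, where a different substituent was swapped at the same kind of position with no effect beyond the scatter. Nothing in the data points to a direction, so no step beyond the scatter is expected in this assay. The estimated step is a 1.2-fold higher number from compound 3 to compound 4 (0.07 log units; within the scatter), and compound 4 is expected to give about 75000 nM, within a range from 40000 nM to 150000 nM.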

Compound 4, half-maximal inhibitory concentration: 82300 nM
For compound 4 the middle estimate is 1.1-fold (0.04 log units) below the measured one; the range from low to high includes it.
By their numbers in this assay, from the lowest: compounds 3, 1, 4 and 2 (each within the scatter of the next).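

In this assay, trifluoromethyl gives way to methoxy on the same aromatic carbon, para to a large group, and this adds a hydrogen-bond acceptor that the leaving group did not have, yet the result is only a 1.3-fold higher number from compound 3 to compound 4 (0.11 log units; within the scatter). Methoxy also stays close to the other two substituents: methoxy in place of chloro gives a 1.2-fold lower number from compound 2 to compound 4 (0.07 log units; within the scatter), and 4-methoxyphenyl in place of 3-fluorophenyl gives a 1.1-fold higher number from compound 1 to compound 4 (0.04 log units; within the scatter). So the earlier picture now extends to a group containing oxygen, and the four groups shown on this aromatic ring cannot be told apart in this cell test. No other measurement is available here that could help interpret these numbers.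

From the compounds shown here alone, it remains open whether a group of a different kind on this ring, such as an amine or a carboxylic acid, or a longer chain in place of methoxy, would give a step beyond the scatter. The compounds shown also leave open what a change to the shared core itself, rather than to this ring, would do to the number.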